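Solubility of a cyclohexyl analogue of compound 1

The source may report more compounds than this note shows. Statements on the series, on what has been measured and on what is new or still open speak of the compounds shown alone.

Measured compounds:
compound 1 `c1ccc(CCc2ccc3c(NCCCNCc4ccco4)ccnc3c2)cc1` — 4200 nM
compound 2 `COc1cccc(CNCCCNc2ccnc3cc(CCc4ccccc4)ccc23)c1O` — 4200 nM

In a physicochemical assay for solubility, with a stated time of 18 h, at pH 7.4 (a higher number here means a more soluble compound, a lower number a less soluble compound), compound 1 gives 4200 nM. Compound 2 gives 4200 nM in this assay, and the step of no change at the digits printed from compound 1 to compound 2 (within the scatter) shows that the replacement of 2-hydroxy-3-methoxyphenyl for furan-2-yl on the amine side of the molecule left solubility unmoved.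

Compound 3 `c1coc(CNCCCNc2ccnc3cc(C4CCCCC4)ccc23)c1` has not been measured. It differs from compound 1 on the other side of the shared core: cyclohexyl in place of phenethyl on an aromatic carbon. Among the measured compounds shown here, no measured step touches this part of the structure; the only measured step, from compound 1 to compound 2, alters the amine side and says nothing about cyclohexyl or phenethyl. With no guidance from the measured pair, the change is expected to give a step no larger than the scatter, a 1.2-fold higher number from compound 1 to compound 3 (0.08 log units; within the scatter). Compound 3 is therefore estimated at 5000 nM in this assay, within the range 2000 nM to 12000 nM.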

Compound 3, solubility: 4200 nM
The estimate for compound 3 lay 1.2-fold (0.08 log units) above the measured number; the measured number falls inside the stated range.
By their numbers in this assay, from the lowest: compounds 1, 2 and 3 (each within the scatter of the next).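

Among the compounds shown here, the earlier compounds changed only the amine side of the molecule, so this is the first reading at the aromatic carbon on the other side of the shared core. In this assay, cyclohexyl in place of phenethyl gives no change at the digits printed from compound 1 to compound 3 (within the scatter). At this position, then, a non-aromatic ring of 6 heavy atoms stands in for a group of 8 heavy atoms carrying an aromatic ring with no shift in solubility beyond the scatter, although nothing shown explains why.

On these data alone, it remains open whether an amine, a carboxylic acid or a longer chain on this aromatic carbon would move the solubility. Also open, as far as these compounds go, is whether cyclohexyl would read the same when paired with the 2-hydroxy-3-methoxyphenyl group of compound 2.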